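Cytotoxicity notes: a smaller ring group in compound 3

The source may report more compounds than this note shows. Statements on the series, on what has been measured and on what is new or still open speak of the compounds shown alone.

In an ADME assay on Huh7.5.1 cells (Homo sapiens) for cytotoxicity, read by ATP content, with a stated time of 48 h (on this read-out lower numbers stand for higher toxicity in this test and higher numbers for lower toxicity in this test), compound 1 (`Cc1ccc(C)c(-c2nc(CN3CCC(C(=O)NCCCN4C[C@H](C)C[C@H](C)C4)CC3)c(C)o2)c1`) gives 4070 nM and compound 2 (`Cc1ccccc1-c1nc(CN2CCC(C(=O)NCCCN3CC(C)(C)CC(C)(C)C3)CC2)c(C)o1`) gives 4380 nM on the same scale. For the measured compounds named here, these two values lie within the usual scatter of each other, so compound 2 stands level with compound 1 on the only numbers available. Going by the values given here, the two compounds differ in more than one place, and no step between measured compounds isolates a single change.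

Compound 3 (`Cc1ccccc1-c1nc(CN2CCC(C(=O)NCCCN3CCCCC3)CC2)c(C)o1`) is the next case. Against compound 2 the whole difference is this: a group of 6 heavy atoms (5 carbon, 1 nitrogen; one six-membered non-aromatic ring with 1 hetero atom) in place of a group of 10 heavy atoms (9 carbon, 1 nitrogen; one six-membered non-aromatic ring with 1 hetero atom), on a saturated chain carbon, three bonds along the chain from an amide-type nitrogen and nothing else in the structure changes. Among the compounds with values here, with no measured step to lean on, the expectation is weakly supported. A moderate step toward higher numbers is expected in this assay and would mean lower toxicity in this test, although a result within the scatter of compound 2 would be no surprise. The estimated step is a 1.8-fold higher number from compound 2 to compound 3 (0.26 log units; within the scatter) in size. For compound 3 the estimated value is 8000 nM with an expected range from 3500 nM to 20000 nM in this test.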

Compound 3, half-maximal cytotoxic concentration: 18100 nM
Beside the measured number, compound 3's estimate is 2.3-fold (0.35 log units) below it; the measured number falls inside the stated range.
By their numbers in this assay, from the lowest: compounds 1 and 2 (each within the scatter of the next); then compound 3.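

In this assay the series gains its first comparison that isolates a single change (a 4.1-fold higher number from compound 2 to compound 3 (0.62 log units; beyond the scatter)), and this step lies beyond the scatter. It shows that the read-out responds to the group on a saturated chain carbon, three bonds along the chain from an amide-type nitrogen, with the higher number standing for lower toxicity in this test. Both groups are one six-membered non-aromatic ring with 1 hetero atom and carry no net charge, so the difference computed between them is the heavy-atom count, with piperidin-1-yl the group with fewer heavy atoms, yet no measured property of either group accompanies this result, and the step stands without an explanation.

From the compounds shown here alone, with a single step, it remains open whether the same change would give a similar shift on the core of compound 1, or whether the number follows the size of the group in any regular way. Also open, going by these compounds, is how a morpholin-4-yl ring, an open-chain dimethylamino group or a longer chain to the amide-type nitrogen would read at this place.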